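A few compounds are considered here, and "the series" means these few. Any claim that something is new, unique, unknown or untested is made for them only; others in the source may bear on it.

Measured compounds:
compound 1 `COc1cc(/C=C2\CN(C)C/C(=C\c3cccnc3)C2=O)cc(OC)c1OC` — 20400 nM
compound 2 `CN1C/C(=C\c2cccnc2)C(=O)/C(=C/c2ccccc2F)C1` — 5420 nM
compound 3 `COc1cc(/C=C2\CN(C)C/C(=C\c3ccncc3)C2=O)cc(OC)c1OC` — 9130 nM

Three compounds were tested in a functional assay on SMMC-7721 cells (Homo sapiens) for cytotoxicity, read by MTT assay, with a stated time of 24 h; on this read-out lower numbers stand for stronger inhibition and higher numbers for weaker inhibition. Compound 1 `COc1cc(/C=C2\CN(C)C/C(=C\c3cccnc3)C2=O)cc(OC)c1OC` gives 20400 nM in this assay, compound 3 `COc1cc(/C=C2\CN(C)C/C(=C\c3ccncc3)C2=O)cc(OC)c1OC` gives 9130 nM, and compound 2 `CN1C/C(=C\c2cccnc2)C(=O)/C(=C/c2ccccc2F)C1` gives 5420 nM. Compound 1 and compound 3 differ in one place only, namely (pyridin-4-yl in place of pyridin-3-yl on a double-bonded chain carbon bound to a double-bonded ring carbon), and this change gave a 2.2-fold lower number from compound 1 to compound 3 (0.35 log units; beyond the scatter). Compound 2 carries a different core from compound 1; the difference between the two cores is not broken down here. Its number stands apart from compound 1 but not from compound 3 within the usual scatter.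

Compound 4 `CN1C/C(=C\c2ccncc2)C(=O)/C(=C/c2ccccc2F)C1` has not been measured. It differs from compound 2 in the same way: pyridin-4-yl in place of pyridin-3-yl on a double-bonded chain carbon bound to a double-bonded ring carbon. The place is the same in words for both pairs, so the same change is made on the core of compound 2. Because the earlier step gave a 2.2-fold lower number from compound 1 to compound 3 (0.35 log units; beyond the scatter), the step for compound 4 is expected to be about a 1.9-fold lower number from compound 2 to compound 4 (0.29 log units; within the scatter). Compound 4 is therefore estimated at 2800 nM, with the expected range from 1200 nM to 6500 nM.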

Compound 4, half-maximal inhibitory concentration: 7000 nM
Compound 4: the middle estimate sits 2.5-fold (0.40 log units) below what was measured; measured number outside the range, above it.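

In this assay, the change from pyridin-3-yl to pyridin-4-yl on the core of compound 2 gave a 1.3-fold higher number from compound 2 to compound 4 (0.11 log units; within the scatter), so no shift can be claimed for it on this core. The change therefore does not carry over as a fixed step between the two cores, and the earlier step cannot be taken as a guide to this one: the same change on two cores in this assay, a 2.2-fold lower number (0.35 log units; beyond the scatter) from compound 1 to compound 3 and a 1.3-fold higher number (0.11 log units; within the scatter) from compound 2 to compound 4, 2.9-fold (0.46 log units) apart, beyond the scatter of two such steps

This rests on a single pair for each core in one cell assay, and it does not show why the two cores respond differently or how the change would behave on any third core.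

The compounds shown leave open how pyridin-2-yl would behave in the same place on either core, and whether a plain phenyl group there would show the same split between them. Also open, from the compounds shown here alone, is whether the two cores would part in the same way in a cell line other than this one.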